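The source may report more compounds than this note shows. Statements on the series, on what has been measured and on what is new or still open speak of the compounds shown alone.

Compound 1, with the structure `CC(=O)Oc1ccc(/C=C/C(=O)OCCSc2nc(-c3ccc(S(C)(=O)=O)cc3)n(-c3ccc(F)cc3)n2)cc1OC(C)=O`, and compound 2, with the structure `CC(=O)Oc1ccc(/C=C/C(=O)OCCSc2nc(-c3ccc(S(N)(=O)=O)cc3)n(-c3ccc(F)cc3)n2)cc1OC(C)=O`, share one core and differ in a single place. In an assay on cells (strain Sprague-Dawley) for inhibition of Polyunsaturated fatty acid 5-lipoxygenase (Rattus norvegicus), with a stated time of 30 min (a lower number here means a stronger inhibitor, a higher number a weaker inhibitor), compound 1 gives 1050 nM, and compound 2 gives 1060 nM. The change between them, (amino in place of methyl on a sulfonyl sulfur), produced a step of a 1.0-fold higher number from compound 1 to compound 2 (0.00 log units; within the scatter), so the two numbers say the same thing.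

Compound 3, with the structure `CS(=O)(=O)c1ccc(-c2nc(SCCOC(=O)/C=C/c3ccc(O)c(O)c3)nn2-c2ccccc2)cc1`, is built on a different core; how its core differs from that of compound 1 is not broken down here. In this assay compound 3 gives 850 nM, a number that lies within the scatter of both compound 1 and compound 2.

Compound 4, with the structure `NS(=O)(=O)c1ccc(-c2nc(SCCOC(=O)/C=C/c3ccc(O)c(O)c3)nn2-c2ccccc2)cc1`, carries the same change relative to compound 3, namely (amino in place of methyl on a sulfonyl sulfur), with the same surroundings as the change from compound 1 to compound 2. Because the earlier step was a 1.0-fold higher number from compound 1 to compound 2 (0.00 log units; within the scatter), the step in this assay is expected to be no change at the digits printed from compound 3 to compound 4 (within the scatter). Compound 4 is therefore estimated to give 850 nM, expected between 450 nM and 1600 nM.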

Compound 4, half-maximal inhibitory concentration: 800 nM
The estimate for compound 4 lay 1.1-fold (0.03 log units) above the measured number; low and high end bracket the measured number.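

In this assay the exchange of methyl for amino on a sulfonyl sulfur gives a 1.1-fold lower number from compound 3 to compound 4 (0.03 log units; within the scatter) and so reads the same on both cores: the same change on two cores in this assay, a 1.0-fold higher number (0.00 log units; within the scatter) from compound 1 to compound 2 and a 1.1-fold lower number (0.03 log units; within the scatter) from compound 3 to compound 4, 1.1-fold (0.03 log units) apart, within the scatter of two such steps. For these two pairs, then, the exchange carries from the core of compound 1 to the core of compound 3 with no readable difference in the size of the step. Neither step lies beyond the scatter, however, so the pairs do not show that an exchange with a real effect on one core would carry over to the other, and two pairs make no rule for the whole series.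

Going by these compounds, it remains open how a larger group on the sulfonyl sulfur, such as ethyl or dimethylamino, would read on either core. The compounds shown also leave open what a longer chain in place of the one linking the sulfur to the ester would do to these numbers.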